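Notes on the tail change from compound 1 to compound 3

This account rests on a few compounds, and the source may have more. Where it says the series, first, only, none or still open, it means among the compounds named here.

For the measured compounds named here, compound 1 `Cn1nnnc1SCC(=O)Nc1ccc(-c2nc(-c3ccccc3)c(-c3ccccc3)n2C)cc1` gives 72.5% in a functional assay on HT-29 cells (Homo sapiens) for cytotoxicity, read by MTT assay, with a stated time of 24 h, tested at 16 ug/mL (a higher number here means a stronger effect of the compound at the concentration tested, a lower number a weaker effect), and stands highest of the two numbers known so far. Its nearest neighbour is compound 2 `Cn1ccnc1SCC(=O)Nc1ccc(-c2nc(-c3ccccc3)c(-c3ccccc3)n2C)cc1`, which gives 36.5% in this assay; the step is a number 36 percentage points lower from compound 1 to compound 2 (beyond the scatter).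

Compound 3 `Cn1c(-c2ccc(NC(=O)CN3CCN(c4ccccc4)CC3)cc2)nc(-c2ccccc2)c1-c1ccccc1` is unmeasured. Compared with compound 1 the change is: 4-phenylpiperazin-1-yl in place of (1-methyl-1H-tetrazol-5-yl)sulfanyl on a saturated chain carbon bound to a carbonyl carbon.

Going by the values given here, only one measured step touches the same part of the molecule, and it altered just the ring on the sulfur, giving a number 36 percentage points lower from compound 1 to compound 2 (beyond the scatter). Among the compounds with values here, the present change is broader, since the whole sulfanyl group leaves and an unrelated group enters, so the one precedent gives only a weak lead: this region appears sensitive, and the single example points downward. A step beyond the scatter is expected for compound 3, most likely downward but with wide uncertainty, a number 22.5 percentage points lower from compound 1 to compound 3 (beyond the scatter). Compound 3 is therefore estimated at 50% in this assay, within a range from 20% to 85%.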

Compound 3, a percentage reported as activity, at one concentration (the size of the read-out at that concentration, not a potency): 55.4%
The estimate for compound 3 lay 5.4 percentage points below the measured number; measured number inside the range.
By their numbers in this assay, from the lowest: compound 2; then compound 3; then compound 1.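

The place on a saturated chain carbon bound to a carbonyl carbon does not depend on a sulfanyl link for an effect in this assay: 4-phenylpiperazin-1-yl, which has no sulfur and no five-membered aromatic ring, gives a number 17.1 percentage points lower from compound 1 to compound 3 (beyond the scatter), and a number 18.9 percentage points higher from compound 2 to compound 3 (beyond the scatter). The new group therefore falls between the two sulfanyl groups, so a change at this place can raise the number as well as lower it. The data offer no measured basis for explaining this order.

From the compounds shown here alone, it remains open whether the piperazine ring or its phenyl group accounts for the number of compound 3; 4-methylpiperazin-1-yl, morpholin-4-yl or an open-chain amine such as diethylamino would help separate the two. A single concentration also leaves the potency of all three compounds open.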